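The source may hold more compounds than are shown below. What is called first, only, known or untested is meant among the compounds shown, and "the series" means these compounds.

Compound 3 `COc1cc(-c2nccn2CC(C)C)cc(OC)c1OC` stands only at a limit in a functional assay on MDA-MB-231 cells (Homo sapiens) for antiproliferative activity, read by MTT assay, with a stated time of 72 h; on this read-out higher numbers stand for weaker inhibition and lower numbers for stronger inhibition: compound 3 returns > 100000 nM, which is the ceiling of the assay and not a number, the ceiling described as the limit of > 100000 nM in this assay, at which 2 of the 3 values shown sit. Compound 1 `CCn1ccnc1-c1cc(OC)c(OC)c(OC)c1` likewise returns a limit in this assay, > 100000 nM. Going by the values given here, compound 2 `CCCCn1ccnc1-c1cc(OC)c(OC)c(OC)c1` gives 70400 nM in this assay, the only number in the set. The measured steps are small or unreadable: an at least 1.4-fold lower number from compound 1 to compound 2 (0.15 log units; that floor lies within the scatter), an at least 1.4-fold higher number from compound 2 to compound 3 (0.15 log units; that floor lies within the scatter), and a step that the two limits leave unreadable from compound 1 to compound 3.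

Compound 4 `COc1cc(-c2nccn2-c2cccc(C)c2)cc(OC)c1OC` differs from compound 3 by 3-methylphenyl in place of isobutyl on an aromatic nitrogen. The three measured steps all exchange one saturated chain for another at or near the ring nitrogen; none brings an aromatic ring onto that nitrogen, so they bear on the step to compound 4 only in showing that every chain variant so far sits at or close to the limit. No direction beyond the scatter can be read from them for this change. Compound 4 is therefore expected to give about 70000 nM in this assay, within 20000 nM to 300000 nM. The step to compound 4 is estimated as an at least 1.4-fold lower number from compound 3 to compound 4 (0.15 log units; that floor lies within the scatter), with a real chance that only a limit is again reported.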

Compound 4, half-maximal inhibitory concentration: 11700 nM
The estimate for compound 4 lay 6.0-fold (0.78 log units) above the measured number, outside the stated range (below it).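

Going by these compounds alone, the step of a 6.0-fold lower number from compound 2 to compound 4 (0.78 log units; beyond the scatter) is the first in this assay with a number at both ends that lies beyond the scatter, and it comes from placing an aromatic ring on the aromatic nitrogen. The three saturated chains leave the series at or close to the limit, whereas 3-methylphenyl at this position, next to the ring atom that bears a large group, moves the read-out clearly lower, so the group on this nitrogen can change the result. The other two comparisons, an at least 8.5-fold lower number from compound 3 to compound 4 (0.93 log units; beyond the scatter) and an at least 8.5-fold lower number from compound 1 to compound 4 (0.93 log units; beyond the scatter) are floors and not sizes, because compound 1 and compound 3 both stand at the ceiling: the limit of > 100000 nM in this assay, at which 2 of the 4 values shown sit.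

The compounds shown leave open whether the gain comes from the aromatic ring itself or needs its methyl group, which a plain phenyl would separate. They also leave open how the series responds to a ring carrying an amine or a carboxylic acid in place of that methyl, or to a benzyl group, which would set a saturated carbon between this nitrogen and the aromatic ring.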